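Ethyl extension on the chain of compound 2

This account rests on a few compounds, and the source may have more. Where it says the series, first, only, none or still open, it means among the compounds named here.

Of the compounds shown here, two have been measured in a functional assay on COLO 205 cells (Homo sapiens) for inhibition, read by MTT assay, with a stated time of 24 h; on this read-out lower numbers stand for stronger inhibition and higher numbers for weaker inhibition. Compound 1 `Fc1ccc(-c2cc(/C=N/c3ccccc3)on2)cc1` gives 33100 nM in this assay. Compound 2 `CCc1cc2ccccc2nc1-c1cc(-c2ccccc2)no1` returns only a limit in this assay, > 100000 nM, so no number is known for it. Among the two values shown, compound 2 is the one that sits at the limit (the limit of > 100000 nM in this assay, at which 1 of the 2 values shown sits); the two compounds differ in more than one place, so no step between them is given.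

Compound 3 `CCCCc1cc2ccccc2nc1-c1cc(-c2ccccc2)no1` is not yet measured. It differs from compound 2 by ethyl in place of hydrogen on a saturated chain carbon, two bonds along the chain from an aromatic carbon. Among the compounds with values here, no measured step in this assay bears on this change, so neither size nor direction can be read from the series. The expected step is a step that the limit leaves unreadable from compound 2 to compound 3, that is, none beyond the scatter, with a limit the most likely outcome. Compound 3 is estimated at 120000 nM, within a range from 40000 nM to 400000 nM.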

Compound 3, half-maximal inhibitory concentration: > 100000 nM
Compound 3 gave a limit, no number; the forecaster's own chance of this, stated with the estimate: 70%; the middle value lies beyond the limit too.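

Compound 2 and compound 3 both return only a limit, so no step between them can be read: the limit of > 100000 nM in this assay, at which 2 of the 3 values shown sit.

The compounds shown leave open whether ethyl in place of hydrogen on this chain changes inhibition at all, and what actual values compound 2 and compound 3 have.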